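The compounds below may be only part of what the source reports. "The series", "measured", "known", "first", "only" and "open" are said of these compounds alone.

Working notes on the series. Compound 3 `C=C(Cl)C(=O)Nc1cc(Nc2nc(C)cc(-c3cn(C)c4ccccc34)n2)c(OC)cc1N(C)CCN(C)C` gives 2230 nM in a functional assay on NCI-H1975 cells (Homo sapiens) for antiproliferative activity, read by MTT assay, with a stated time of 72 h (a lower number here means a stronger inhibitor, a higher number a weaker inhibitor), the lowest of the three numbers recorded so far. Compound 1 `CC/C=C\C(=O)Nc1cc(Nc2nccc(-c3cn(C)c4ccccc34)n2)c(OC)cc1N(C)CCN(C)C` gives 3860 nM in this assay, within the scatter of compound 3, and compound 2 `C=CC(=O)Nc1cc(Nc2nc(C)cc(-c3cn(C)c4ccccc34)n2)c(OC)cc1N(C)CCN(C)C` gives 4810 nM, separated from compound 3 by a 2.2-fold lower number from compound 2 to compound 3 (0.33 log units; beyond the scatter).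

Compound 4 `CC/C=C\C(=O)Nc1cc(Nc2nc(C)cc(-c3cn(C)c4ccccc34)n2)c(OC)cc1N(C)CCN(C)C` differs from compound 3 by but-1-en-1-yl in place of 1-chloroethenyl on a carbonyl carbon. Among the measured compounds shown here, no measured pair isolates this exact change. The nearest guide is the step from compound 2 to compound 3, where a 2.2-fold lower number from compound 2 to compound 3 (0.33 log units; beyond the scatter) followed the chloro for hydrogen; removing the chlorine and extending the chain would be expected to give that gain back. Compound 1 and compound 2, which differ in two places including the but-1-en-1-yl for ethenyl swap, show numbers within the scatter of each other, so the chain extension itself is not expected to shift the number much. Compound 4 is therefore expected to land near compound 1, with an estimated step of a 1.8-fold higher number from compound 3 to compound 4 (0.25 log units; within the scatter), giving 4000 nM with a range of 2000 nM to 8000 nM.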

Compound 4, half-maximal inhibitory concentration: 1990 nM
The estimate for compound 4 lay 2.0-fold (0.30 log units) above the measured number; the whole stated range lies above it.
By their numbers in this assay, from the lowest: compounds 4, 3, 1 and 2 (each within the scatter of the next, the first and the last beyond it).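

In this assay, but-1-en-1-yl and 1-chloroethenyl on the carbonyl carbon are not separated (a 1.1-fold lower number from compound 3 to compound 4 (0.05 log units; within the scatter)), while but-1-en-1-yl in place of vinyl gives a step beyond the scatter (a 2.4-fold lower number from compound 2 to compound 4 (0.38 log units; beyond the scatter)), so among these compounds a number of this size does not depend on chlorine on the chain. Methyl in place of hydrogen on an aromatic carbon can now be read alone, and the step stays within the scatter (a 1.9-fold lower number from compound 1 to compound 4 (0.29 log units; within the scatter)). No measurement here gives a reason for any of these steps.

Open, as far as these compounds go, is whether a longer chain or a chain carrying a dimethylamino group on the carbonyl carbon would move the number further, and whether ethyl or chloro in place of the methyl on the aromatic carbon would do so.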